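Replacing the nitrile on a Bcl-2 inhibitor with a trifluoromethyl ketone

The source may report more compounds than this note shows. Statements on the series, on what has been measured and on what is new or still open speak of the compounds shown alone.

Measured compounds:
- compound 1, `Cc1cc(S(=O)(=O)NC(=O)c2ccc(N3CCN(Cc4ccccc4-c4ccc(Cl)cc4)CC3)cc2)ccc1N[C@H](CCN(C)C)CSc1ccccc1`: < 1 nM
- compound 2, `CN(C)CC[C@H](CSc1ccccc1)Nc1ccc(S(=O)(=O)NC(=O)c2ccc(N3CCN(Cc4ccccc4-c4ccc(Cl)cc4)CC3)cc2)cc1C#N`: < 1 nM

In an assay on isolated protein for displacement of a labelled ligand from Apoptosis regulator Bcl-2 (Homo sapiens), read by fluorescence polarization (a higher number here means a weaker inhibitor, a lower number a stronger inhibitor), compound 1 gives < 1 nM, which is a limit of the assay rather than a number. Compound 2 gives < 1 nM in this assay, again a limit and not a number. For the measured compounds named here, the only measured step, a step that the two limits leave unreadable from compound 1 to compound 2, is therefore unreadable: both values sit at the limit of < 1 nM in this assay, at which 2 of the 2 values shown sit, so whether the change from methyl to cyano helped, hurt or did nothing cannot be told from these two results.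

Compound 3, `CN(C)CC[C@H](CSc1ccccc1)Nc1ccc(S(=O)(=O)NC(=O)c2ccc(N3CCN(Cc4ccccc4-c4ccc(Cl)cc4)CC3)cc2)cc1C(=O)C(F)(F)F`, carries the change ((trifluoromethyl)carbonyl in place of cyano on an aromatic carbon). Going by the values given here, no measured step bears directly on this exchange, and the one step that exists cannot be sized. What the two measured compounds do show is that the shared core tolerates at least two different small groups at this aromatic carbon while staying at the limit. Compound 3 is expected to stay close to that level, with some chance of a measurable loss as the entering group is larger than the leaving one. The expected step is an at least 1.5-fold higher number from compound 2 to compound 3 (0.17 log units; that floor lies within the scatter). Compound 3 is estimated at 1.5 nM, within 0.3 nM to 8 nM.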

Compound 3, inhibition constant: < 1 nM
Compound 3: only a limit was reported (the forecaster's own chance of this, stated with the estimate: 40%); middle value at least 1.5-fold (0.17 log units) from the limit.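

In this assay compound 3 gives < 1 nM, a limit and not a number. The steps from compound 1 and from compound 2 to compound 3 therefore cannot be read: the limit of < 1 nM in this assay, at which 3 of the 3 values shown sit. Left open is how compound 1, compound 2 and compound 3 truly compare, and so whether methyl, cyano or (trifluoromethyl)carbonyl on this aromatic carbon makes any difference.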